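Swapping Chloro for Fluoro on a Cell-Growth Inhibitor

A few compounds are considered here, and "the series" means these few. Any claim that something is new, unique, unknown or untested is made for them only; others in the source may bear on it.

Going by the values given here, compound 1 `Cc1cc(Nc2cc(-c3ccc(Cl)cc3)[nH]n2)n2nc(SCc3ccc(Br)cc3)nc2n1` was tested in a functional assay on MCF7 cells (Homo sapiens) for inhibition, read by MTT assay, with a stated time of 72 h (a lower number here means a stronger inhibitor, a higher number a weaker inhibitor), and gives 3620 nM, the lowest of the two numbers measured so far. Compound 2 `Cc1cc(Nc2cc(-c3ccccc3)[nH]n2)n2nc(SCc3cccc4ccccc34)nc2n1` gives 7560 nM in this assay, a higher number that lies beyond the usual scatter. Compound 3 `Cc1cc(Nc2cc(-c3ccc(F)cc3)[nH]n2)n2nc(SCc3ccc(Br)cc3)nc2n1` differs from compound 1 in a single place: fluoro in place of chloro on an aromatic carbon. Among the compounds with values here, no measured pair shows this same change, so its size is unknown here. A small step toward a higher number, near the edge of the scatter, is expected a 1.4-fold higher number from compound 1 to compound 3 (0.14 log units; within the scatter). Compound 3 is therefore estimated at 5000 nM, with a range from 2000 nM to 12000 nM.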

Compound 3, half-maximal inhibitory concentration: 4570 nM
Estimate against measurement, compound 3: 1.1-fold (0.04 log units) above; low and high end bracket the measured number.
By their numbers in this assay, from the lowest: compounds 1, 3 and 2 (each within the scatter of the next, the first and the last beyond it).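

Going by these compounds alone, the first direct comparison at this place on the ring comes from replacing chloro with fluoro, a change of one atom for one atom: in this assay there is a 1.3-fold higher number from compound 1 to compound 3 (0.10 log units; within the scatter). That step lies within the usual scatter, so this assay does not separate compound 1 from compound 3. Nothing measured here offers an explanation for this result.

On these data alone, it remains open whether a larger or quite different group at this place, such as an amine or a carboxylic acid, would separate itself from these two halogens. As far as these compounds go, it is also open whether the same swap would behave alike with another group elsewhere on the molecule.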